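Swapping methoxy for fluoro on the benzylamine arm

The compounds below may be only part of what the source reports. "The series", "measured", "known", "first", "only" and "open" are said of these compounds alone.

Compound 1, `CCN1CCN(c2nc(NCc3ccc(F)cc3)nc3c2ncn3CCCN2CCCC2)CC1`, gives 40 nM in an assay on HEK293 cells for antagonist activity at Toll-like receptor 9 (Homo sapiens), read by spectrophotometry; on this read-out higher numbers stand for weaker inhibition and lower numbers for stronger inhibition.
Compound 2, `COc1ccc(CNc2nc(N3CCN(C4CCCC4)CC3)c3ncn(CCCN4CCCC4)c3n2)cc1`, gives 240 nM in this assay.

Compound 2 holds the higher of the two numbers measured, and its gap to compound 1 lies beyond the scatter. Compound 3, `Fc1ccc(CNc2nc(N3CCN(C4CCCC4)CC3)c3ncn(CCCN4CCCC4)c3n2)cc1`, has not been measured. It differs from compound 2 in one place: fluoro in place of methoxy on an aromatic carbon. For the measured compounds named here, compound 1 also carries the fluoro group, but it differs from compound 3 elsewhere as well, so no measured pair shows this change alone. The change is expected to lower the number somewhat, with the step from compound 2 to compound 3 estimated at a 2.0-fold lower number from compound 2 to compound 3 (0.30 log units; within the scatter). For compound 3 the expected value in this assay is 120 nM, with a range from 40 nM to 360 nM.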

Compound 3, half-maximal inhibitory concentration: 100 nM
Compound 3: middle estimate off by 1.2-fold (0.08 log units), on the high side; low and high end bracket the measured number.
By their numbers in this assay, from the lowest: compound 1; then compound 3; then compound 2.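

Fluoro in place of methoxy on the aromatic carbon gives a 2.4-fold lower number from compound 2 to compound 3 (0.38 log units; beyond the scatter), which shows that this one change, with the rest of the molecule held fixed, moves the number in this assay by more than the usual scatter. Compound 3 also isolates a second place: cyclopentyl in place of ethyl on the ring amine nitrogen gives a 2.5-fold higher number from compound 1 to compound 3 (0.40 log units; beyond the scatter), so the group on that nitrogen matters as well, with ethyl giving the lower number of this pair. Nothing measured here explains either step.

On these data alone, it remains open whether the fluoro-for-methoxy step holds with ethyl on that nitrogen. Also open, as far as these compounds go, is how chloro, a nitrile or plain hydrogen would read on the same aromatic carbon.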